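The compounds below may be only part of what the source reports. "The series", "measured", "known", "first", "only" and "open" are said of these compounds alone.

Compound 1, `COc1cccc(COc2ccc(-c3nn(CCC#N)c(=S)o3)cc2)c1`, was tested in an assay for inhibition of Amine oxidase [flavin-containing] A (Rattus norvegicus) (on this read-out higher numbers stand for weaker inhibition and lower numbers for stronger inhibition), where compound 1 gives 8100 nM. Compound 2, `Cc1cccc(COc2ccc(-c3nn(CCC#N)c(=S)o3)cc2)c1`, carries methyl in place of methoxy on an aromatic carbon; in this assay compound 2 gives 14000 nM, and the step of a 1.7-fold higher number from compound 1 to compound 2 (0.24 log units; within the scatter) is small enough to count as no real movement.

Compound 3, `COc1cccc(COc2ccc(C3=NN(CCC#N)C(=O)CO3)cc2)c1`, shares the benzyl ether portion of compound 1 but has a different core; how the two cores differ is not broken down here. In this assay compound 3 gives 32000 nM, the highest number of the three measured, and its gaps to compound 2 and to compound 1 both lie beyond the usual scatter.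

Compound 4, `Cc1cccc(COc2ccc(C3=NN(CCC#N)C(=O)CO3)cc2)c1`, stands to compound 3 as compound 2 stands to compound 1: it carries methyl in place of methoxy on an aromatic carbon. The surroundings of the change read the same way in both pairs, so this is the same change made on the core of compound 3 rather than on the core of compound 1. For the measured compounds named here, since the one measured instance of this change, a 1.7-fold higher number from compound 1 to compound 2 (0.24 log units; within the scatter), stayed within the scatter, compound 4 is expected to differ from compound 3 by a similarly modest amount, with an estimated step of a 1.6-fold higher number from compound 3 to compound 4 (0.19 log units; within the scatter) in this assay. Going by the values given here, on that basis the estimate for compound 4 is 50000 nM, with a plausible range from 20000 nM to 120000 nM; the single prior example and the weak activity of compound 3, 32000 nM, leave this estimate loosely held.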

Compound 4, half-maximal inhibitory concentration: 40000 nM
Compound 4: the middle estimate sits 1.3-fold (0.10 log units) above what was measured, within the range that was stated.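

In this assay, methyl in place of methoxy on the core of compound 3 gives a 1.3-fold higher number from compound 3 to compound 4 (0.10 log units; within the scatter), so compound 3 and compound 4 cannot be told apart, just as compound 1 and compound 2 could not be on the other core. Set side by side, the two instances agree: the same change on two cores in this assay, a 1.7-fold higher number (0.24 log units; within the scatter) from compound 1 to compound 2 and a 1.3-fold higher number (0.10 log units; within the scatter) from compound 3 to compound 4, 1.4-fold (0.14 log units) apart, within the scatter of two such steps. For the compounds shown here, this shows that, on these two cores, the swap from 3-methoxybenzyl to 3-methylbenzyl leaves the read-out within the scatter, but it rests on only two pairs and does not show that the same would hold on any further core, nor does it test whether a change with a real effect on one core would carry over to the other.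

The compounds shown leave open whether a group other than methoxy or methyl on that aromatic carbon, such as an amine, a carboxylic acid or a chlorine atom, would move the number beyond the scatter on either core. They also leave open whether a longer chain carrying the nitrile would do so, and whether any such step would then match from one core to the other.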